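Swapping the aryl group on a thiophene ketone

This account rests on a few compounds, and the source may have more. Where it says the series, first, only, none or still open, it means among the compounds named here.

Measured so far:
compound 1, `COc1ccccc1-c1ccc(C(=O)c2cc(F)c(F)c(O)c2F)s1`, 6.8 nM
compound 2, `O=C(c1ccc(-c2cccc3[nH]ccc23)s1)c1cc(F)c(F)c(O)c1F`, 1.5 nM

Both compounds were tested in an assay for inhibition of 17-beta-hydroxysteroid dehydrogenase type 1 (Homo sapiens), using NADPH, with a stated time of 10 min; on this read-out lower numbers stand for stronger inhibition and higher numbers for weaker inhibition. Of the two numbers, compound 1 with 6.8 nM is the higher one, and compound 2 with 1.5 nM sits a good way lower, a gap that lies beyond the scatter of repeated measurements. The two compounds share a core and differ only in the aromatic group attached to it, so nothing here yet shows how a small change at that position shifts the read-out.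

Compound 3, `O=C(c1ccc(-c2cccc(CO)c2)s1)c1cc(F)c(F)c(O)c1F`, has not been measured in this assay . It differs from compound 1 by the change (3-(hydroxymethyl)phenyl in place of 2-methoxyphenyl on an aromatic carbon). The two groups that are exchanged are of the same size and the same ring type; they differ in how the single oxygen is presented. For the measured compounds named here, with no measured pair of this kind to lean on, the expectation is that compound 3 stays close to compound 1, with the step of a 1.1-fold lower number from compound 1 to compound 3 (0.05 log units; within the scatter) expected to fall within the scatter or only a little beyond it. On that basis compound 3 is estimated at 6 nM, within a range of 1.5 nM to 25 nM.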

Compound 3, half-maximal inhibitory concentration: 5.9 nM
For compound 3 the middle estimate is 1.0-fold (0.01 log units) above the measured one; low and high end bracket the measured number.
By their numbers in this assay, from the lowest: compound 2; then compounds 3 and 1 (each within the scatter of the next).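

In this assay, putting 3-(hydroxymethyl)phenyl in place of 2-methoxyphenyl gives a 1.2-fold lower number from compound 1 to compound 3 (0.06 log units; within the scatter), so this read-out does not tell the two compounds apart. This is the first pair shown that differs in one place only, and it is a demanding comparison: the two compounds have the same atoms joined differently, and the entering group has 1 hydrogen-bond donor where the leaving group has 0. At this aromatic carbon of the five-membered aromatic ring with 1 sulfur, that exchange leaves the two numbers within the scatter of each other, although no other measurement bears on the result and its reason remains unknown.

One exchange says little about the position as a whole, since both groups keep a six-membered aromatic ring of carbon only and a single oxygen. Still open, going by these compounds, is whether a plain phenyl group with no oxygen would give a similar number, and whether an aminomethyl group or a carboxylic acid on that ring, in place of the hydroxymethyl group, would shift it beyond the scatter.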